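Bromo in Place of Hydrogen on the Shared Core

This account rests on a few compounds, and the source may have more. Where it says the series, first, only, none or still open, it means among the compounds named here.

Compound 2 `C=C1C[C@]23C[C@@]1(O)CC[C@H]2c1ccc(O)c(C)c1[C@@H]3Cn1cc(-c2ccc(C)cc2)nn1` stands at the edge of the numbers shown. In a functional assay on MCF7 cells (Homo sapiens) for cytotoxicity, read by MTT assay, with a stated time of 4 days (on this read-out higher numbers stand for weaker inhibition and lower numbers for stronger inhibition), compound 2 reaches only the limit of the assay, > 20000 nM, so no number is known for it. One of the two values shown sits at the limit of > 20000 nM in this assay, at which 1 of the 2 values shown sits. For the measured compounds named here, compound 1 `C=C1C[C@]23C[C@@]1(O)CC[C@H]2c1cc(Br)c(O)c(C)c1[C@@H]3Cn1cc(-c2ccc(C(F)(F)F)cc2)nn1`, which carries bromo on the shared core together with a trifluoromethyl group on the pendant aryl, gives 8100 nM in this assay; as compound 1 and compound 2 differ in two places, their two values show only that compound 1 is measurable where compound 2 is not. Compound 3 `C=C1C[C@]23C[C@@]1(O)CC[C@H]2c1cc(Br)c(O)c(C)c1[C@@H]3Cn1cc(-c2ccc(C)cc2)nn1` differs from compound 2 by bromo in place of hydrogen on an aromatic carbon. Since compound 1 gives a measurable 8100 nM with bromo present, the step of an at least 1.6-fold lower number from compound 2 to compound 3 (0.22 log units; that floor lies within the scatter) is expected to run toward stronger inhibition. As far as these compounds go, how large that step is remains open, as the value of compound 2 is a limit of the assay. Compound 3 is therefore estimated at 12000 nM, within 4000 nM to 40000 nM.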

Compound 3, half-maximal inhibitory concentration: > 20000 nM
Compound 3: no number, only a limit; the forecaster's own chance of this, stated with the estimate: 35%; at least 1.6-fold (0.22 log units) between middle value and limit.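

In this assay compound 3 gives > 20000 nM, a limit and not a number, so bromo in place of hydrogen on the aromatic carbon ortho to the hydroxy group does not by itself yield a measurable value, and the step between compound 2 and compound 3 cannot be read: the limit of > 20000 nM in this assay, at which 2 of the 3 values shown sit.

With bromo held constant, methyl in place of trifluoromethyl on an aromatic carbon gives an at least 2.4-fold higher number from compound 1 to compound 3 (0.39 log units; beyond the scatter). Among the compounds shown, a measurable value appears only with bromo and trifluoromethyl together.

As far as these compounds go, whether trifluoromethyl on the pendant aryl gives a measurable value with hydrogen in place of bromo stays open. From the compounds shown here alone, what an amine or a chlorine atom would do at this aromatic carbon also stays open.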